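The source may report more compounds than this note shows. Statements on the series, on what has been measured and on what is new or still open speak of the compounds shown alone.

Of the compounds shown here, three have so far been measured in a functional assay on MCF7 cells (Homo sapiens) for cytotoxicity, read by MTT assay, with a stated time of 24 h; a lower number here means a stronger inhibitor, a higher number a weaker inhibitor. Compound 1 `CN(C)CCCN1CCN(CC(=O)Nc2ccc(-c3nc4cc(F)ccc4o3)cc2)CC1` gives 14800 nM. Compound 2 `Cc1ccc2oc(-c3ccc(NC(=O)CN4CCN(CCCN(C)C)CC4)cc3)nc2c1` gives 19100 nM in this assay; it differs from compound 1 by methyl in place of fluoro on an aromatic carbon, and that step was a 1.3-fold higher number from compound 1 to compound 2 (0.11 log units; within the scatter). Compound 3 `Cc1cc(-c2nc3cc(F)ccc3o2)ccc1NC(=O)CN1CCN(CCCN(C)C)CC1` gives 7770 nM in this assay; its core differs from the core of compound 1 by methyl in place of hydrogen on an aromatic carbon, and that step was a 1.9-fold lower number from compound 1 to compound 3 (0.28 log units; within the scatter). Compound 4 `Cc1ccc2oc(-c3ccc(NC(=O)CN4CCN(CCCN(C)C)CC4)c(C)c3)nc2c1` has not yet been measured. It differs from compound 3 by methyl in place of fluoro on an aromatic carbon, the same change as seen between compound 1 and compound 2, since the place is described in identical words. Because the earlier step was a 1.3-fold higher number from compound 1 to compound 2 (0.11 log units; within the scatter), the expected step in this assay is a 1.3-fold higher number from compound 3 to compound 4 (0.11 log units; within the scatter). Compound 4 is therefore estimated at 10000 nM, with a likely range from 5000 nM to 20000 nM.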

Compound 4, half-maximal inhibitory concentration: 19800 nM
Compound 4: middle estimate off by 2.0-fold (0.30 log units), on the low side, and the stated range covers the measured number.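

In this assay, the change from 5-fluoro-1,3-benzoxazol-2-yl to 5-methyl-1,3-benzoxazol-2-yl gave a 2.5-fold higher number from compound 3 to compound 4 (0.41 log units; beyond the scatter), and its size on the two cores cannot be told apart: the same change on two cores in this assay, a 1.3-fold higher number (0.11 log units; within the scatter) from compound 1 to compound 2 and a 2.5-fold higher number (0.41 log units; beyond the scatter) from compound 3 to compound 4, 2.0-fold (0.30 log units) apart, within the scatter of two such steps. Methyl in place of hydrogen on an aromatic carbon gave a 1.0-fold higher number from compound 2 to compound 4 (0.02 log units; within the scatter), and this change likewise shows no difference that can be told apart between its two cores: the same change on two cores in this assay, a 1.9-fold lower number (0.28 log units; within the scatter) from compound 1 to compound 3 and a 1.0-fold higher number (0.02 log units; within the scatter) from compound 2 to compound 4, 2.0-fold (0.30 log units) apart, within the scatter of two such steps. For the compounds shown here, this shows that both changes carried over between these cores within the scatter, but with only two steps per change it does not show that their sizes are the same or that they would hold on any other core.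

The compounds shown leave open whether chloro or methoxy on that same aromatic carbon would follow the same course. They also leave open whether these steps would persist with a longer chain on the piperazine.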